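A few compounds are considered here, and "the series" means these few. Any claim that something is new, unique, unknown or untested is made for them only; others in the source may bear on it.

In a functional assay on CCRF-CEM cells (Homo sapiens) for cytotoxicity, read by sulforhodamine B assay, with a stated time of 48 h (on this read-out higher numbers stand for weaker inhibition of growth and lower numbers for stronger inhibition of growth), compound 1 `ClCc1ccccc1Cn1cnc2c(Cl)nc(Cl)nc21` gives 90 nM. In this assay compound 2 `ClCc1ccccc1Cn1cnc2c(Cl)ncnc21` gives 3230 nM, and compound 3 `ClCc1ccccc1Cn1cnc2ncnc(Cl)c21` gives 3540 nM in this assay, a value within the usual scatter of compound 2. Compound 2 and compound 3 contain the same atoms joined differently; the difference between the two cores is not broken down here.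

From compound 2 to compound 1 the change chloro in place of hydrogen on an aromatic carbon brought a 36-fold lower number from compound 2 to compound 1 (1.55 log units; beyond the scatter). The same change, (chloro in place of hydrogen on an aromatic carbon), leads from compound 3 to compound 4 `ClCc1ccccc1Cn1cnc2nc(Cl)nc(Cl)c21`, which has not yet been measured. This step is expected to be about a 35-fold lower number from compound 3 to compound 4 (1.55 log units; beyond the scatter) because the same change on the other core gave a 36-fold lower number from compound 2 to compound 1 (1.55 log units; beyond the scatter). Compound 4 is therefore estimated at 100 nM, expected to fall between 40 nM and 300 nM.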

Compound 4, concentration for total growth inhibition: 300 nM
Beside the measured number, compound 4's estimate is 3.0-fold (0.48 log units) below it; measured number inside the range.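

Carried onto the core of compound 3, chloro in place of hydrogen on an aromatic carbon again lowered the number in this assay, giving a 12-fold lower number from compound 3 to compound 4 (1.07 log units; beyond the scatter). The direction of the step held on both cores, but its size did not carry over unchanged: the same change on two cores in this assay, a 36-fold lower number (1.55 log units; beyond the scatter) from compound 2 to compound 1 and a 12-fold lower number (1.07 log units; beyond the scatter) from compound 3 to compound 4, 3.0-fold (0.48 log units) apart, beyond the scatter of two such steps. Within the data shown here, with only two cores, this does not show how the change would behave on any further core, and the numbers alone do not explain why the two steps differ in size.

The compounds shown leave open whether an amine or a methoxy group on that same aromatic carbon would lower the number on either core. They also leave open whether a fluoro or bromo group would give a step like that of chloro.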